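The source may hold more compounds than are shown below. What is called first, only, known or untested is meant among the compounds shown, and "the series" means these compounds.

Measured compounds:
- compound 1, `COc1ccc(-c2c(C#N)c(N)c(C#N)c(SC)c2-c2ccc(OC)cc2)cc1`: 6.9%
- compound 2, `CSc1c(C)c(-c2ccc(Cl)cc2)c(C#N)c(N)c1C#N`: 12.5%

Both measured compounds share a core carrying two nitrile groups, an amino group and a methylthio group. In an assay on isolated protein for inhibition of glucose-6-phosphatase catalytic subunit 1 (Homo sapiens), tested at 100 uM (a higher number here means more inhibition at the concentration tested (going by the name of the read-out), a lower number less inhibition), compound 1 gives 6.9%. In this assay compound 2 gives 12.5%. The two numbers are separated by less than the usual scatter of such a measurement, so compound 2 and compound 1 cannot be told apart on these data; both show only weak inhibition at the tested concentration.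

Compound 3, `COc1ccc(-c2c(C)c(SC)c(C#N)c(N)c2C#N)cc1`, is not yet measured. It differs from compound 2 in one place: methoxy in place of chloro on an aromatic carbon. Among the measured compounds shown here, no step between measured compounds is available for this change, so its effect is unknown. Given that compound 1, which also carries methoxy groups, gives 6.9%, and compound 2 gives 12.5%, the expectation for compound 3 is a step of a number 2.5 percentage points lower from compound 2 to compound 3 (within the scatter), that is, no movement beyond the scatter. The value of compound 3 in this assay is estimated at 10%, within a range of 2% to 22%.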

Compound 3, a percentage reported as inhibition, at one concentration (the size of the read-out at that concentration, not a potency): 37.5%
For compound 3 the middle estimate is 27.5 percentage points below the measured one; the measured number lies above the stated range.
By their numbers in this assay, from the lowest: compounds 1 and 2 (each within the scatter of the next); then compound 3.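

In this assay, among the compounds shown here, the change to methoxy in place of chloro on an aromatic carbon, para to a large group, gives a number 25 percentage points higher from compound 2 to compound 3 (beyond the scatter) and is the first sign that the read-out responds to the group at this position, since compound 1 and compound 2 differ in more than one place and offered no such comparison. The step for methyl in place of 4-methoxyphenyl on an aromatic carbon gives a number 30.6 percentage points higher from compound 1 to compound 3 (beyond the scatter) and shows that a methoxy group does not by itself go with higher inhibition: compound 1 carries methoxy groups and stays low, so the outcome for methoxy depends on what occupies the other position on the shared core. Nothing measured here bears on why either step occurs.

From the compounds shown here alone, with a single step at each position, neither change can yet be called a trend, and it remains open whether a hydroxyl, an ethoxy, a dimethylamino group or a fluoro at the chloro position would match methoxy. Going by these compounds, it is equally open whether an ethyl, a longer chain or an unsubstituted phenyl in place of the methyl would keep the inhibition of compound 3.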